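The source may report more compounds than this note shows. Statements on the series, on what has been measured and on what is new or still open speak of the compounds shown alone.

Compound 1 `CC(C)Cc1cc2oc(=O)n(CCC(=O)O)c2cc1Cl` gives 794 nM.
Compound 2 `C[C@@H](Oc1cc2onc(CCC(=O)O)c2cc1Cl)c1ccc(Cl)cn1` gives 3.98 nM.
Compound 3 `C[C@@H](Oc1cc2oc(=O)n(CCC(=O)O)c2cc1Cl)c1ccc(Cl)cn1` gives 100 nM.

All three were tested in an assay on HEK293 cells for inhibition of kynurenine 3-monooxygenase (Homo sapiens), read by LC-MS, with a stated time of 20 h; a higher number here means a weaker inhibitor, a lower number a stronger inhibitor. Among them compound 1 has the highest number and so is the weakest inhibitor of the three: compound 3 lies nearer to it and compound 2 furthest away, both gaps beyond the usual scatter. Compound 4 `CCc1cc2oc(=O)n(CCC(=O)O)c2cc1Cl` has not yet been measured. It differs from compound 1 in one place: methyl in place of isopropyl on a saturated chain carbon bound to an aromatic carbon. Among the measured compounds shown here, no measured pair here shows what shortening this chain does, so the expectation rests only on the smallness of the change. A small step is expected, leaning toward a weaker inhibitor and possibly not beyond the scatter, so the step of a 1.9-fold higher number from compound 1 to compound 4 (0.28 log units; within the scatter) is estimated. Compound 4 is expected to give 1500 nM, within a range from 500 nM to 5000 nM.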

Compound 4, half-maximal inhibitory concentration: 316 nM
For compound 4 the middle estimate is 4.7-fold (0.68 log units) above the measured one, and the stated range ends above it.
By their numbers in this assay, from the lowest: compound 2; then compound 3; then compound 4; then compound 1.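

Replacing isopropyl with methyl on a saturated chain carbon bound to an aromatic carbon (the same difference reads isobutyl to ethyl) gives a 2.5-fold lower number from compound 1 to compound 4 (0.40 log units; beyond the scatter), so this is a modest step toward a stronger inhibitor. Among the compounds shown here, it is the first direct sign that this position responds to the size of the chain, and here the shorter chain is the better one. Nothing available explains why the number falls. On these data alone, with only these two chains compared in this place, it remains open whether a propyl chain, a cyclopropyl ring or an amine would continue this direction or reverse it.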